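Cyano in Place of Nitro on a Shared Core

A few compounds are considered here, and "the series" means these few. Any claim that something is new, unique, unknown or untested is made for them only; others in the source may bear on it.

Among the measured compounds shown here, in a functional assay on EKVX cells (Homo sapiens) for inhibition, read by sulforhodamine B assay, with a stated time of 48 h, tested at 10 uM (on this read-out higher numbers stand for more inhibition of growth at the one concentration tested and lower numbers for less inhibition of growth), compound 1 `CCOC(=O)c1ccc(Nc2ccnc(SCC(=O)c3ccc([N+](=O)[O-])cc3)n2)cc1` gives 27%, the higher of the two numbers measured so far. Compound 2 `O=C(O)c1ccc(Nc2ccnc(SCC(=O)c3ccc(C(F)(F)F)cc3)n2)cc1` gives 10% in this assay, a figure that sits clearly under that of compound 1. Compound 3 `CCOC(=O)c1ccc(Nc2ccnc(SCC(=O)c3ccc(C#N)cc3)n2)cc1` differs from compound 1 by cyano in place of nitro on an aromatic carbon. For the measured compounds named here, no measured pair shows this change, so the expected step of a number 7 percentage points lower from compound 1 to compound 3 (within the scatter) is a small loss at most, likely not beyond the scatter. Compound 3 is therefore estimated at 20%, between 5% and 38%.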

Compound 3, percent growth inhibition at one concentration: 26%
The estimate for compound 3 lay 6 percentage points below the measured number; the measured number falls inside the stated range.
By their numbers in this assay, from the lowest: compound 2; then compounds 3 and 1 (each within the scatter of the next).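

Among the compounds shown here, exchanging 4-nitrophenyl for 4-cyanophenyl gives the first step at this position that can be read directly: in this assay it is a number 1 percentage points lower from compound 1 to compound 3 (within the scatter). On this read-out, compound 1 and compound 3 cannot be told apart, so at this place, para to a large group, cyano can stand in for nitro on the shared core, at least in this one pair. No measurement shown here gives a reason for this result.

On these data alone, whether an amine or a methoxy group at this place would give a similar number remains open. For the compounds shown here, no pair differing in one place compares the ethyl ester with the carboxylic acid.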